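Swapping a sulfur for an oxygen in the ring on the sulfonyl chain

This account rests on a few compounds, and the source may have more. Where it says the series, first, only, none or still open, it means among the compounds named here.

The three measured compounds share a sulfonyl group on a short saturated chain that ends in a small five-membered non-aromatic ring. Compound 1 `COc1ccc(-c2nn(-c3ccccc3)c(-c3ccc(C)cc3)c2S(=O)(=O)CC2=NCCO2)cc1` gives 68.7% in a functional assay, tested at 75 ug/mL (on this read-out higher numbers stand for a stronger effect at the one concentration tested and lower numbers for a weaker effect), and compound 3 `Cc1ccc(C2CNN=C2S(=O)(=O)CC2=NCCO2)cc1` gives 42.1% in the same read-out. Compound 2 `COc1ccc(-c2noc(-c3ccc(C)cc3)c2S(=O)(=O)CC2=NCCS2)cc1` stands apart: in this assay compound 2 is reported as "not active" (no number reported), so no single number is known for it, only that it showed no measurable effect at the one concentration tested.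

Compound 4 `COc1ccc(-c2noc(-c3ccc(C)cc3)c2S(=O)(=O)CC2=NCCO2)cc1` keeps the core of compound 2 and changes only the terminal ring. The difference is a group of 5 heavy atoms (3 carbon, 1 nitrogen, 1 oxygen; one five-membered non-aromatic ring with 2 hetero atoms) in place of a group of 5 heavy atoms (3 carbon, 1 nitrogen, 1 sulfur; one five-membered non-aromatic ring with 2 hetero atoms), on a saturated chain carbon bound to a sulfonyl sulfur. Within the data shown here, the two measured compounds that carry this oxygen-containing ring, compound 1 and compound 3, both give a numbered read-out, while the one compound with the sulfur-containing ring, compound 2, does not. Among the measured compounds shown here, no step between measured compounds is available to set the size of this change, so the expectation rests on that contrast alone. A move from no measurable effect to a moderate read-out is expected for compound 4, with wide uncertainty. Compound 4 is estimated at 30%, within a range from 5% to 60%.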

Compound 4, a percentage reported as activity, at one concentration (the size of the read-out at that concentration, not a potency): 72%
For compound 4 the middle estimate is 42 percentage points below the measured one; the measured number lies above the stated range.
By their numbers in this assay, from the lowest: compound 3; then compounds 1 and 4 (each within the scatter of the next).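

Among these compounds, compound 2 is reported as not active, with no number, so although in this assay compound 4 gives 72% no step from compound 2 to compound 4 can be read. How large the effect of swapping the sulfur-containing ring for the oxygen-containing ring really is stays open, and nothing measured here explains the contrast.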